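The source may report more compounds than this note shows. Statements on the series, on what has been measured and on what is new or still open speak of the compounds shown alone.

For the measured compounds named here, compound 2 `COc1ccc2c(c1)CC(c1nc3ccc(-c4ccnc(N)n4)cc3[nH]1)CO2` gives 2 nM in an assay on isolated protein for inhibition of Rho-associated protein kinase 2 (Homo sapiens) (a higher number here means a weaker inhibitor, a lower number a stronger inhibitor), the only plain number in this small set. Compound 1 `Nc1nccc(-c2ccc3nc(C4COc5ccc(C(=O)NCc6ccccc6)cc5C4)[nH]c3c2)n1` sits at < 1 nM, which is a limit of this assay rather than a number (the limit of < 1 nM in this assay, at which 1 of the 2 values shown sits). Going by the values given here, the one measured step, an at least 2.0-fold higher number from compound 1 to compound 2 (0.30 log units; that floor lies within the scatter), swaps a much larger group for the methoxy, so it bears only loosely on what follows. Compound 3 `CC(C)Oc1ccc2c(c1)CC(c1nc3ccc(-c4ccnc(N)n4)cc3[nH]1)CO2` differs from compound 2 by isopropyl in place of methyl on an oxygen on an aromatic ring. Among the compounds with values here, no measured step alters the group on that oxygen, so the step from compound 2 to compound 3 is expected to be small, a 2.0-fold higher number from compound 2 to compound 3 (0.30 log units; within the scatter). Compound 3 is therefore estimated at 4 nM, within 1 nM to 15 nM.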

Compound 3, half-maximal inhibitory concentration: 296 nM
Compound 3: the middle estimate sits 74-fold (1.87 log units) below what was measured, and the stated range ends below it.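

In this assay, a change on this oxygen that looked minor proves decisive: isopropyl in place of methyl gives a 150-fold higher number from compound 2 to compound 3 (2.17 log units; beyond the scatter). Benzylcarbamoyl on the same aromatic carbon, in compound 1, gives no such weakening, so a larger group there does not by itself bring a higher number. The step of an at least 290-fold higher number from compound 1 to compound 3 (2.47 log units; beyond the scatter) is only a floor, as the figure for compound 1 is a limit: the limit of < 1 nM in this assay, at which 1 of the 3 values shown sits.

Going by these compounds, what stays open is whether ethoxy would stay near compound 2 or already fall towards compound 3. A straight propoxy chain would show whether the branching of isopropyl matters.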